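Replacing Cyclohexyl with Acetyl in a Series at Its Limit

A few compounds are considered here, and "the series" means these few. Any claim that something is new, unique, unknown or untested is made for them only; others in the source may bear on it.

Of the compounds shown here, three sharing one core have been tested in a functional assay on C8166 cells (Homo sapiens) for antiproliferative activity, read by MTT assay; a lower number here means that less compound is tolerated, a higher number that more compound is tolerated. Compound 1 (`Cc1cc(C)cc(S(=O)(=O)c2c(C(=O)NCC(=O)NN)[nH]c3ccc(Cl)cc23)c1`) gives only a limit of the assay (> 100 uM). Compound 2 (`CNNC(=O)c1[nH]c2ccc(Cl)cc2c1S(=O)(=O)c1cc(C)cc(C)c1`) also gives only a limit (> 100 uM). Compound 3 (`Cc1cc(C)cc(S(=O)(=O)c2c(C(=O)NNC3CCCCC3)[nH]c3ccc(Cl)cc23)c1`), the starting point here, likewise gives only a limit (> 100 uM). It therefore has no number of its own, and the two other results offer none either. The whole series stands in one place (the limit of > 100 uM in this assay, at which 3 of the 3 values shown sit).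

Compound 4 (`CC(=O)NNC(=O)c1[nH]c2ccc(Cl)cc2c1S(=O)(=O)c1cc(C)cc(C)c1`) carries acetyl in place of cyclohexyl on an amine nitrogen. The closest measured change lies at that nitrogen (a step that the two limits leave unreadable from compound 2 to compound 3). The two remaining steps alter the same side chain (a step that the two limits leave unreadable from compound 1 to compound 2) (a step that the two limits leave unreadable from compound 1 to compound 3). None of the three has a readable size, so they offer no shift to carry over. No step beyond the scatter is therefore expected in this assay, and no direction can be assigned. The expected step is small (a step that the limit leaves unreadable from compound 3 to compound 4). Another limit is the likeliest report. Compound 4 is estimated at (150 uM) with an expected range (from 70 uM to 320 uM).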

Compound 4, half-maximal toxic concentration: > 100 uM
Compound 4: no number, only a limit (the forecaster's own chance of this, stated with the estimate: 85%); the middle value is on the limit's open side.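

In this assay, compound 4 gives only a limit, like compound 1, compound 2 and compound 3, so none of its steps to those compounds can be read: the limit of > 100 uM in this assay, at which 4 of the 4 values shown sit.

The compounds shown leave open what concentration any of the four tolerates in this assay, and whether acetyl, methyl or cyclohexyl on the amine nitrogen makes any difference there.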